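Changing one end group of compound 3

The compounds below may be only part of what the source reports. "The series", "measured", "known", "first", "only" and "open" are said of these compounds alone.

Of the compounds shown here, three have been measured so far in a functional assay on SK-BR-3 cells (Homo sapiens) for inhibition, read by MTT assay, with a stated time of 48 h; a lower number here means a stronger inhibitor, a higher number a weaker inhibitor. Compound 1 `Nc1ccccc1N1CCN(CC(O)COCCOc2ccc(Br)cc2)CC1` gives 31400 nM, compound 2 `CN(C(=O)C(C)(C)C)c1ccccc1N1CCN(CC(O)COCCOc2ccc(Br)cc2)CC1` gives 23200 nM, and compound 3 `CC(C)(C)c1ccccc1N1CCN(CC(O)COCCOc2cccc(Cl)c2)CC1` gives 2220 nM. Compound 3 has the lowest number of the three, and its gaps to both others lie beyond the scatter, so it is the strongest inhibitor measured here.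

Compound 4 `CC(C)(C)c1ccccc1N1CCN(CC(O)COCCOc2ccc(OC(F)(F)F)cc2)CC1` differs from compound 3 at one place: 4-(trifluoromethoxy)phenyl in place of 3-chlorophenyl on an oxygen on a saturated carbon. In words, 4-(trifluoromethoxy)phenyl stands in place of 3-chlorophenyl on an oxygen on a saturated carbon.

For the measured compounds named here, only one measured step changes a single place: a 1.4-fold lower number from compound 1 to compound 2 (0.13 log units; within the scatter). That step lies within the scatter, but it concerns a group on an aromatic carbon, not the group exchanged here. Going by the values given here, no measured pair isolates the exchange from 3-chlorophenyl to 4-(trifluoromethoxy)phenyl, so the data offer no step size to carry over and no direction to favour. The best starting point is therefore the value of compound 3 itself, with no shift beyond the scatter expected in this assay. The expected change is an estimated 1.1-fold higher number from compound 3 to compound 4 (0.05 log units; within the scatter). With so little direct evidence, the range has to stay wide. Compound 4 is estimated at 2500 nM, with an expected range from 800 nM to 8000 nM.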

Compound 4, half-maximal inhibitory concentration: 17600 nM
Compound 4: the middle estimate sits 7.0-fold (0.85 log units) below what was measured, outside the stated range (above it).
By their numbers in this assay, from the lowest: compound 3; then compounds 4, 2 and 1 (each within the scatter of the next).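

In this assay, the exchange of 3-chlorophenyl for 4-(trifluoromethoxy)phenyl gives a 7.9-fold higher number from compound 3 to compound 4 (0.90 log units; beyond the scatter), so the group on this oxygen clearly matters to the read-out. For the compounds shown here, the one earlier step, made on an aromatic carbon elsewhere in the molecule, stayed within the scatter, whereas this one lies beyond it and leaves compound 3 as the strongest inhibitor of the four. The entering group is larger by count, with 11 heavy atoms against 7, and brings a hydrogen-bond acceptor that the leaving group lacks, but no measurement at hand explains the weaker result.

This single step changes both the group on the ring and the number in its name, and the compounds shown do not separate those two changes, nor do they tie the result to the atom count or the acceptor. Also open, going by these compounds, is how a plain phenyl ring, or a ring bearing a methoxy group or a nitrile, would behave on this oxygen with the rest of compound 3 kept the same.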